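A Second Chloro on the Fused Core of Compound 1

The compounds below may be only part of what the source reports. "The series", "measured", "known", "first", "only" and "open" are said of these compounds alone.

Compound 1 `ClCc1ccc(Cn2cnc3c(Cl)ncnc32)cc1` was tested in a functional assay on OVCAR-5 cells (Homo sapiens) for cytotoxicity, read by sulforhodamine B assay, with a stated time of 48 h (on this read-out lower numbers stand for stronger inhibition of growth and higher numbers for weaker inhibition of growth), where compound 1 gives 9230 nM. Among the three measured compounds this is the second highest number. The nearest value belongs to compound 3 `ClCc1ccccc1Cn1cnc2nc(Cl)nc(Cl)c21`, which in this assay gives 5750 nM; the gap to compound 1 lies within the usual scatter, so the two are not separated. Compound 2 `Nc1nc(Cl)c2ncn(Cc3ccccc3CCl)c2n1` gives 39800 nM in this assay, a number that sits above that of compound 1 by more than the scatter.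

Compound 4 `ClCc1ccc(Cn2cnc3c(Cl)nc(Cl)nc32)cc1` has not yet been measured. It differs from compound 1 by chloro in place of hydrogen on an aromatic carbon. Going by the values given here, no pair of measured compounds isolates this change, so its effect is not known directly. The closest point of reference is compound 3, whose fused core likewise carries two chloro groups and which gives 5750 nM in this assay. On that basis the step of a 1.5-fold lower number from compound 1 to compound 4 (0.19 log units; within the scatter) is expected to be small and toward a lower number, quite possibly not beyond the scatter. Compound 4 is expected to give about 6000 nM in this assay, with a likely range from 2000 nM to 18000 nM.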

Compound 4, concentration for total growth inhibition: 34700 nM
Beside the measured number, compound 4's estimate is 5.8-fold (0.76 log units) below it; the measured number lies above the stated range.
By their numbers in this assay, from the lowest: compounds 3 and 1 (each within the scatter of the next); then compounds 4 and 2 (each within the scatter of the next).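

In this assay, chloro in place of hydrogen on the aromatic carbon between two ring nitrogen atoms gives a 3.8-fold higher number from compound 1 to compound 4 (0.58 log units; beyond the scatter) and so moves the number beyond the scatter, showing that this position is not indifferent to the change. Two chloro groups on the core do not settle the number on their own: compound 3 gives 5750 nM and compound 4 gives 34700 nM in this assay, though the two differ only in where the chloromethyl group sits. Nothing in the data available explains this step.

Going by these compounds, it remains open whether the same change would move the number in the same direction with the chloromethyl group placed as in compound 3. Also open, on these data alone, is how a methoxy group or a fluoro atom on this carbon would compare with chloro.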